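One Fluorinated Group Swapped for Another

The compounds below may be only part of what the source reports. "The series", "measured", "known", "first", "only" and "open" are said of these compounds alone.

In a functional assay on MCF7 cells (Homo sapiens) for inhibition, read by MTT assay, with a stated time of 72 h (on this read-out lower numbers stand for stronger inhibition and higher numbers for weaker inhibition), compound 1 `NS(=O)(=O)c1ccc2c(c1)C(=O)C(=O)N2` gives > 50000 nM, which is a limit of the assay and not a number. Going by the values given here, compound 2 `NS(=O)(=O)c1ccc2c(c1)C(=O)C(=O)N2Cc1ccc(SC(F)(F)F)cc1` gives 2600 nM, the only actual number so far. Compound 3 `NS(=O)(=O)c1ccc2c(c1)C(=O)C(=O)N2Cc1ccc(C(F)(F)F)cc1` has trifluoromethyl in place of (trifluoromethyl)sulfanyl on an aromatic carbon. Among the compounds with values here, no measured pair of compounds shows what this exchange does, so the expectation starts from compound 2 at 2600 nM. The estimated change, a 1.5-fold higher number from compound 2 to compound 3 (0.19 log units; within the scatter), is expected to stay within the usual scatter, leaning slightly toward weaker inhibition. Compound 3 is expected at 4000 nM, with an estimated range of 1500 nM to 12000 nM.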

Compound 3, half-maximal inhibitory concentration: 8200 nM
Compound 3: middle estimate off by 2.1-fold (0.31 log units), on the low side; the range from low to high includes it.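

In this assay, putting trifluoromethyl in place of (trifluoromethyl)sulfanyl gives a 3.2-fold higher number from compound 2 to compound 3 (0.50 log units; beyond the scatter). Going by these compounds alone, this is the first readable step, and it shows that inhibition responds to a small exchange on this aromatic carbon, with the sulfur-containing group giving the stronger inhibition of the two. Within the data shown here, compound 1 remains a limit of the assay, and no step to it can be read: the limit of > 50000 nM in this assay, at which 1 of the 3 values shown sits.

Still open, on these data alone, is how other groups at this place, such as an amine or a carboxylic acid, would compare with these two.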